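Shortening the Ketone Side Chain from Compound 3 to Compound 4

The source may hold more compounds than are shown below. What is called first, only, known or untested is meant among the compounds shown, and "the series" means these compounds.

Of the compounds shown here, three built on one shared core have been measured in an assay on HEK293 cells for positive allosteric modulation of metabotropic glutamate receptor 2 (Rattus norvegicus), read by thallium flux, with a stated time of 2.5 min; a higher number here means that more compound is needed for the effect, a lower number that less compound is needed. Compound 1 `Cc1c(OCCCCOc2ccc(C(=O)O)cc2Cl)ccc(C(=O)CC2CCCC2)c1O` gives 237 nM. Compound 2 `CCC(=O)c1ccc(OCCCCOc2ccc(F)c(C(=O)O)c2)c(C)c1O` gives 124 nM. Compound 3 `Cc1c(OCCCCOc2ccc(F)c(C(=O)O)c2)ccc(C(=O)CC2CCCC2)c1O` gives 699 nM, the highest of the three numbers: there is a 2.9-fold higher number from compound 1 to compound 3 (0.47 log units; beyond the scatter), and there is a 5.6-fold higher number from compound 2 to compound 3 (0.75 log units; beyond the scatter).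

Compound 4 `CCCC(=O)c1ccc(OCCCCOc2ccc(F)c(C(=O)O)c2)c(C)c1O` differs from compound 3 at a single place: ethyl in place of cyclopentyl on a saturated chain carbon bound to a carbonyl carbon. Within the data shown here, only one measured step touches this position, the change from methyl to cyclopentyl seen as a 5.6-fold higher number from compound 2 to compound 3 (0.75 log units; beyond the scatter), a modest rise. Going from cyclopentyl to ethyl undoes part of that same change, so the number for compound 4 is expected to fall back toward that of compound 2, though perhaps not all the way, since ethyl is not methyl. The expected step is a 3.2-fold lower number from compound 3 to compound 4 (0.50 log units; beyond the scatter). On that basis compound 4 is estimated at 220 nM, with a plausible range from 90 nM to 500 nM.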

Compound 4, half-maximal effective concentration: 74 nM
Beside the measured number, compound 4's estimate is 3.0-fold (0.47 log units) above it; the measured number lies below the stated range.
By their numbers in this assay, from the lowest: compounds 4, 2 and 1 (each within the scatter of the next, the first and the last beyond it); then compound 3.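

In this assay, swapping cyclopentyl for ethyl gives a 9.4-fold lower number from compound 3 to compound 4 (0.98 log units; beyond the scatter) and so removes the whole penalty that came with the ring, more than the first comparison could show. The step of a 1.7-fold lower number from compound 2 to compound 4 (0.22 log units; within the scatter) lies within the usual scatter, so methyl in place of hydrogen on a saturated chain carbon, two bonds along the chain from a carbonyl carbon, leaves the number effectively unchanged. Among compound 2, compound 3 and compound 4, then, the higher number goes with cyclopentyl and not with a small extension of the straight chain. Nothing given here explains why cyclopentyl costs so much. The compounds shown leave open how large this group can grow before the number rises, and whether a butyl chain or a cyclopropyl ring in the same place would behave like ethyl or like cyclopentyl.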